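Replacing 3-hydroxyphenyl in a compound at the limit

The compounds below may be only part of what the source reports. "The series", "measured", "known", "first", "only" and "open" are said of these compounds alone.

Compound 1 `COc1ccc([C@H]2CC(=O)N(C(=O)c3ccccc3)C2)cc1OC1CCCC1` gives > 10000 nM as a limit
Compound 2 `COc1ccc([C@H]2CC(=O)N(c3ccccc3)C2)cc1OC1CCCC1` gives > 10000 nM as a limit
Compound 3 `COc1ccc([C@H]2CC(=O)N(c3cccc(O)c3)C2)cc1OC1CCCC1` gives > 10000 nM as a limit

In a functional assay on HEK293 cells (Homo sapiens) for cytotoxicity (on this read-out lower numbers stand for higher toxicity in this test and higher numbers for lower toxicity in this test), compound 3 stands at > 10000 nM as a limit and not a number. The whole set shares this position, as the limit of > 10000 nM in this assay, at which 3 of the 3 values shown sit, shows. Compound 4 `COc1ccc([C@H]2CC(=O)N(c3ccc(C)c(N)c3)C2)cc1OC1CCCC1` carries 3-amino-4-methylphenyl in place of 3-hydroxyphenyl on an amide-type nitrogen in a ring, and 3-amino-4-methylphenyl in place of 3-hydroxyphenyl on an amide-type nitrogen in a ring gives the count of what changes. For the measured compounds named here, three measured steps bear on this change, namely a step that the two limits leave unreadable from compound 1 to compound 2 and a step that the two limits leave unreadable from compound 1 to compound 3 at that nitrogen and a step that the two limits leave unreadable from compound 2 to compound 3 on an aromatic carbon, but none of them has a readable size. No step beyond the scatter is therefore expected in this assay and no direction can be given. The expected step that the limit leaves unreadable from compound 3 to compound 4 stays within the scatter. For compound 4 the estimate is 15000 nM within an expected range from 6000 nM to 40000 nM and a report as a limit is likely.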

Compound 4, half-maximal cytotoxic concentration: > 10000 nM
Compound 4 was reported as a limit (the forecaster's own chance of this, stated with the estimate: 85%); the middle value lies beyond the limit too.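

Compound 4, like compound 1, compound 2 and compound 3, gives a limit and not a number in this assay, so no step among these compounds can be read: the limit of > 10000 nM in this assay, at which 4 of the 4 values shown sit.

The compounds shown leave open whether any of these changes on the amide-type nitrogen alters toxicity in this assay, and in which direction.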